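The source may hold more compounds than are shown below. What is called first, only, known or untested is meant among the compounds shown, and "the series" means these compounds.

The measured compounds:

Compound 1, `CCCOC(=O)C1=C(C)NC(=O)NC1c1ccoc1`: 11%
Compound 2, `CC1=C(C(=O)OCC(C)C)C(c2ccoc2)NC(=O)N1`: 16%
Compound 3, `CCCOC(=O)C1=C(C)NC(=S)NC1c1ccco1`: 1%

All three were tested in an assay on membranes from HeLa cells for displacement of a labelled ligand from adenosine receptor A3 (Homo sapiens), read by scintillation counting, with a stated time of 180 min, tested at 1 uM; a higher number here means more inhibition at the concentration tested (going by the name of the read-out), a lower number less inhibition. Compound 1 and compound 2 share one core and differ only by methyl in place of hydrogen on a saturated chain carbon bound to two saturated chain carbons. That change gave a number 5 percentage points higher from compound 1 to compound 2 (within the scatter), so the two readings cannot be told apart with confidence.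

Compound 3 carries a different core; how its core differs from that of compound 1 is not broken down here. In this assay compound 3 gives 1%, a reading within the scatter of compound 1 and beyond the scatter of compound 2.

The compound yet to be measured is compound 4, `CC1=C(C(=O)OCC(C)C)C(c2ccco2)NC(=S)N1`. It stands to compound 3 exactly as compound 2 stands to compound 1: the difference is methyl in place of hydrogen on a saturated chain carbon bound to two saturated chain carbons, at the same kind of place as before, so it is the same change made on the other core.

The expectation for compound 4 therefore rests on two things: the small step the same change produced, a number 5 percentage points higher from compound 1 to compound 2 (within the scatter), and the low starting point of compound 3 at 1%. The step expected is a number 4 percentage points higher from compound 3 to compound 4 (within the scatter), which is within the scatter, just as the first one was. Compound 4 is expected to give 5%, most likely somewhere between 0% and 16%.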

Compound 4, a percentage reported as inhibition, at one concentration (the size of the read-out at that concentration, not a potency): 10%
For compound 4 the middle estimate is 5 percentage points below the measured one; the range from low to high includes it.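

In this assay, swapping hydrogen for methyl on a saturated chain carbon bound to two saturated chain carbons, which turns propoxy into isobutoxy, gave a number 9 percentage points higher from compound 3 to compound 4 (within the scatter) on the second core. This does not show that the methyl raises inhibition on either core, since each step taken alone lies within the usual scatter, and all four readings are percentages at one concentration rather than potencies; two cores are also too few to support a rule for the whole series. What can be said is that the change behaved alike on both cores, with no sign that its effect depends on the core, and that the size of the step carried over within the limits of this assay: the same change on two cores in this assay, a number 5 percentage points higher (within the scatter) from compound 1 to compound 2 and a number 9 percentage points higher (within the scatter) from compound 3 to compound 4, 4 percentage points apart, within the scatter of two such steps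

The compounds shown leave open whether a longer chain, such as pentyloxy, or a chain ending in an amine or a carboxylic acid, would move the reading clearly beyond the scatter. They also leave open whether the same small step would hold on a core that starts from a much higher reading, where a change in inhibition would be easier to see.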